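Benzyl-type substituent swap on the shared core

The source may hold more compounds than are shown below. What is called first, only, known or untested is meant among the compounds shown, and "the series" means these compounds.

Measured compounds in a functional assay on TE-1 cells (Homo sapiens) for antiproliferative activity, read by MTT assay, with a stated time of 72 h; a lower number here means a stronger inhibitor, a higher number a weaker inhibitor:
compound 1, `CCCSc1nc(Cl)c2c(n1)N(Cc1cccs1)C(C(=O)N1CCN(C)CC1)N2`, 39400 nM
compound 2, `CCCSc1nc(Cl)c2c(n1)N(Cc1ccccc1)C(C(=O)NCCC1=CCc3ccccc31)N2`, 30000 nM
compound 3, `CCCSc1nc(Cl)c2c(n1)N(Cc1ccccc1)C(C(=O)NCCCc1ccccc1)N2`, 23000 nM

Compound 1 gives the nominally largest of the three numbers, but its gap to compound 2 and to compound 3 is within the scatter, so the three cannot be told apart on these data. For the measured compounds named here, the one step available, a 1.3-fold lower number from compound 2 to compound 3 (0.12 log units; within the scatter), concerns the amide side of the core and lies within the scatter.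

Compound 4, `CCCSc1nc(Cl)c2c(n1)N(CC1CCCCC1)C(C(=O)N1CCN(C)CC1)N2`, differs from compound 1 in one place: cyclohexyl in place of thiophen-2-yl on a saturated chain carbon bound to a nitrogen on an aromatic ring in a ring. Going by the values given here, no measured pair touches this position; the step from compound 2 to compound 3 is at the amide side and does not bear on it. With nothing in this assay speaking for a change, the expectation for compound 4 is a number close to that of compound 1, so that a 1.1-fold lower number from compound 1 to compound 4 (0.05 log units; within the scatter) is expected to be no more than the scatter. The estimate for compound 4 in this assay is 35000 nM, with a range from 10000 nM to 100000 nM.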

Compound 4, half-maximal inhibitory concentration: > 64000 nM
Compound 4 ended at the assay's limit; the forecaster's own chance of this, stated with the estimate: 20%; middle value at least 1.8-fold (0.26 log units) away from the limit.
By their numbers in this assay, from the lowest: compounds 3, 2 and 1 (each within the scatter of the next). At a limit, above all of these: compound 4.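

In this assay compound 4 sits at a limit of the assay, > 64000 nM, which is a limit and not a number. For the compounds shown here, this gives the first reading at this position, on a saturated chain carbon bound to a nitrogen on an aromatic ring in a ring: an at least 1.6-fold higher number from compound 1 to compound 4 (0.21 log units; that floor lies within the scatter). Cyclohexyl in place of thiophen-2-yl therefore gives no sign of a stronger inhibitor, but the true size of the step cannot be read: the limit of > 64000 nM in this assay, at which 1 of the 4 values shown sits.

No step shown is established as lying beyond the scatter, so the influence of this position on the shared core remains unresolved. Still open, going by these compounds, is what a pyridin-3-ylmethyl group or a longer chain such as 2-(thiophen-2-yl)ethyl would give at this position with the amide of compound 1 kept unchanged.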